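Swapping the Ester Group on a Shared Core

The source may hold more compounds than are shown below. What is called first, only, known or untested is meant among the compounds shown, and "the series" means these compounds.

Measured in an ADME assay on HepG2 2.2.15 cells (Homo sapiens) for cytotoxicity; a higher number here means that more compound is tolerated, a lower number that less compound is tolerated:
- compound 1 (`CCCC(=O)OCCc1c(-c2ccccc2Cl)c2cc(Cl)ccc2[nH]c1=O`) gives 52000 nM
- compound 2 (`O=C(OCCc1c(-c2ccccc2Cl)c2cc(Cl)ccc2[nH]c1=O)C1CCCC1`) gives 46000 nM
- compound 3 (`CC(=O)N1CCC(C(=O)OCCc2c(-c3ccccc3Cl)c3cc(Cl)ccc3[nH]c2=O)CC1`) gives 82000 nM

Compound 3 cannot be ranked apart from the other two, since its value lies within the usual scatter of both: a 1.6-fold higher number from compound 1 to compound 3 (0.20 log units; within the scatter) and a 1.8-fold higher number from compound 2 to compound 3 (0.25 log units; within the scatter). Compound 4 (`O=C(OCCc1c(-c2ccccc2Cl)c2cc(Cl)ccc2[nH]c1=O)c1ccc([N+](=O)[O-])cc1`) has not yet been measured. It carries 4-nitrophenyl in place of 1-acetylpiperidin-4-yl on a carbonyl carbon.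

The three measured steps all swap the group on that same carbonyl carbon. Besides the two above, there is a 1.1-fold lower number from compound 1 to compound 2 (0.05 log units; within the scatter). None of them goes beyond the scatter, so no step beyond the scatter is expected in this assay. For the measured compounds named here, still, no measured compound has an aromatic ring on that carbon, so this expectation reaches past the data and the range is kept wide. The expected change is a 1.5-fold lower number from compound 3 to compound 4 (0.17 log units; within the scatter). For compound 4 the estimated value is 55000 nM, with an expected range from 22000 nM to 110000 nM.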

Compound 4, half-maximal cytotoxic concentration: 1600000 nM
For compound 4 the middle estimate is 29-fold (1.46 log units) below the measured one, and the stated range ends below it.
By their numbers in this assay, from the lowest: compounds 2, 1 and 3 (each within the scatter of the next); then compound 4.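

In this assay, for the compounds shown here, the group on this carbonyl carbon proves able to shift the number strongly, something the earlier compounds did not show. Putting 4-nitrophenyl there in place of 1-acetylpiperidin-4-yl (a 20-fold higher number from compound 3 to compound 4 (1.29 log units; beyond the scatter)), cyclopentyl (a 35-fold higher number from compound 2 to compound 4 (1.54 log units; beyond the scatter)) or propyl (a 31-fold higher number from compound 1 to compound 4 (1.49 log units; beyond the scatter)) raises the number far beyond the scatter each time, so the flat picture holds only among compounds 1, 2 and 3, whose groups have no aromatic ring. No measurement shown explains this jump.

With only one aromatic group shown, it stays open whether the jump comes from the aromatic ring or from its nitro group. Plain phenyl, or a phenyl ring carrying an amine or a carboxylic acid instead of the nitro group, would help separate the two.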